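The source may hold more compounds than are shown below. What is called first, only, known or untested is meant among the compounds shown, and "the series" means these compounds.

In an in vitro assay on Sf9 cells for inhibition of Rho-associated protein kinase 2 (Homo sapiens), read by TR-FRET, with a stated time of 25 min (a lower number here means a stronger inhibitor, a higher number a weaker inhibitor), compound 1 `C[N+]1(C)C[C@@H](c2ccccc2)[C@H](c2nc3ccc(-c4cn[nH]c4)cc3c(=O)[nH]2)C1` gives 4 nM, compound 3 `NCc1cccc(C(=O)NC(c2ccc(Cl)cc2)c2nc3ccc(-c4cn[nH]c4)cc3c(=O)[nH]2)c1` gives 20 nM, and compound 2 `O=c1[nH]c([C@@H]2CN(Cc3ccccc3)C[C@H]2c2ccccc2F)nc2ccc(-c3cn[nH]c3)cc12` gives 49 nM. Compound 2 thus carries the highest number of the three, and its gap to compound 3 as well as its gap to compound 1 lies beyond the usual scatter. Compound 4 `O=c1[nH]c([C@@H]2CN(Cc3ccccc3)C[C@H]2c2cccc(F)c2)nc2ccc(-c3cn[nH]c3)cc12` differs from compound 2 only by 3-fluorophenyl in place of 2-fluorophenyl on a saturated ring carbon. Going by the values given here, no measured pair in this set shows the effect of such a change, so the expectation rests on compound 2 alone. The estimate implies a 1.4-fold lower number from compound 2 to compound 4 (0.15 log units; within the scatter), a step expected to stay within the scatter rather than move clearly in either direction. Compound 4 is expected to give 35 nM in this assay, with a range from 10 nM to 120 nM.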

Compound 4, half-maximal inhibitory concentration: 225 nM
The estimate for compound 4 lay 6.4-fold (0.81 log units) below the measured number, outside the stated range (above it).
By their numbers in this assay, from the lowest: compound 1; then compound 3; then compound 2; then compound 4.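

In this assay, swapping 2-fluorophenyl for 3-fluorophenyl on this saturated ring carbon gives a 4.6-fold higher number from compound 2 to compound 4 (0.66 log units; beyond the scatter). Going by these compounds alone, the two compounds have the same atoms, joined differently, so this position responds to where the fluorine sits on the phenyl ring, which the earlier compounds, with no single-place pair among them, could not show. Nothing at hand gives a reason for this step. As far as these compounds go, what 4-fluorophenyl or 2-methoxyphenyl would give at this position stays open. So does whether the same step would appear with a cyclohexylmethyl group in place of the benzyl group.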